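The source may hold more compounds than are shown below. What is called first, only, known or untested is meant among the compounds shown, and "the series" means these compounds.

Measured compounds:
compound 1 `O=S(=O)(Nc1ccc2oc(-c3ccccc3)nc2c1)c1ccc(Cl)cc1`: > 63000 nM
compound 2 `Cc1cccc(S(=O)(=O)Nc2ccc3oc(-c4ccccc4)nc3c2)c1`: > 63000 nM
compound 3 `Cc1cccc(S(=O)(=O)Nc2ccc(-c3nc4ccccc4o3)cc2)c1`: > 63000 nM

All three compounds were tested in an assay on isolated protein for inhibition of malate dehydrogenase, mitochondrial (Sus scrofa), with stated times of 45 min and 30 min; on this read-out higher numbers stand for weaker inhibition and lower numbers for stronger inhibition. In this assay compound 1 gives > 63000 nM, which is a limit of the assay and not a number. Compound 2 gives > 63000 nM, again a limit rather than a number. Compound 3 likewise gives > 63000 nM, a limit of the assay.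

Compound 1 and compound 2 differ in one place: 4-chlorophenyl in place of 3-methylphenyl on a sulfonyl sulfur. The step that the two limits leave unreadable from compound 2 to compound 1 cannot be read, since both values are limits. Compound 2 and compound 3 are built from the same atoms joined differently; the difference between the two cores is not broken down here.

Compound 4 `O=S(=O)(Nc1ccc(-c2nc3ccccc3o2)cc1)c1ccc(Cl)cc1` has not yet been tested in this assay. It stands to compound 3 as compound 1 stands to compound 2: 4-chlorophenyl in place of 3-methylphenyl on a sulfonyl sulfur. The place of the change is described in the same words for both pairs, so it is the same change. Going by the values given here, its one measured instance gave no readable size, and the limit of > 63000 nM in this assay, at which 3 of the 3 values shown sit, is the only pattern the three values offer. For compound 4 the expected step that the limit leaves unreadable from compound 3 to compound 4 is therefore small because compound 3 gives > 63000 nM and that value is a limit of the assay. Compound 4 is expected to give about 100000 nM, within 30000 nM to 400000 nM, most likely again reported only as a limit.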

Compound 4, half-maximal inhibitory concentration: > 63000 nM
Compound 4 was reported as a limit; the forecaster's own chance of this, stated with the estimate: 85%; the middle value does not contradict the limit.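

Compound 4 gives > 63000 nM as a limit of the assay, not as a number. Compound 3 also stands only as a limit, so no size can be read for the step between compound 3 and compound 4. The compounds shown leave open whether any change among them alters inhibition of the enzyme at all, because no value here is more than a limit: the limit of > 63000 nM in this assay, at which 4 of the 4 values shown sit.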